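The source may report more compounds than this note shows. Statements on the series, on what has been measured and on what is new or still open speak of the compounds shown alone.

In an assay on cells for inhibition of HSP60/HSP10 (Homo sapiens), with a stated time of 60 min (a lower number here means a stronger inhibitor, a higher number a weaker inhibitor), compound 3 `COc1ccccc1S(=O)(=O)Nc1ccc2oc(-c3ccccc3)nc2c1` reaches only a limit of the measurement, giving > 100000 nM. Compound 1 `Cc1ccc(S(=O)(=O)Nc2ccc3oc(-c4ccccc4)nc3c2)cc1` likewise stops at a limit in this assay, with > 100000 nM. Compound 2 `C=Cc1ccc(S(=O)(=O)Nc2ccc3oc(-c4ccccc4)nc3c2)cc1` also gives a limit there, > 100000 nM. Because (the limit of > 100000 nM in this assay, at which 3 of the 3 values shown sit), the steps a step that the two limits leave unreadable from compound 1 to compound 2, a step that the two limits leave unreadable from compound 1 to compound 3 and a step that the two limits leave unreadable from compound 2 to compound 3 cannot be sized in either direction. The change leading to compound 4 `O=S(=O)(Nc1ccc2oc(-c3ccccc3)nc2c1)c1cccc(O)c1` is 3-hydroxyphenyl in place of 2-methoxyphenyl on a sulfonyl sulfur. With every measured step unreadable, nothing in the series gives a size or direction for the move from compound 3 to compound 4. Compound 4 is therefore expected to sit near the same limit, with an estimated 150000 nM and a range from 30000 nM to 500000 nM. The implied step that the limit leaves unreadable from compound 3 to compound 4 is expected to be no more than that.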

Compound 4, half-maximal inhibitory concentration: 76000 nM
Compound 4: middle estimate off by 2.0-fold (0.30 log units), on the high side; low and high end bracket the measured number.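

In this assay, 3-hydroxyphenyl on the sulfonyl sulfur gives the only number shown that is not a limit, so the steps to it can at last be given a floor: an at least 1.3-fold lower number from compound 3 to compound 4 (0.11 log units; that floor lies within the scatter), an at least 1.3-fold lower number from compound 2 to compound 4 (0.11 log units; that floor lies within the scatter) and an at least 1.3-fold lower number from compound 1 to compound 4 (0.11 log units; that floor lies within the scatter). Each step is readable only as a floor, and its full size stays unknown: the limit of > 100000 nM in this assay, at which 3 of the 4 values shown sit.

The compounds shown leave open how 2-hydroxyphenyl, 3-methoxyphenyl or 3-aminophenyl on the sulfonyl sulfur would read in this assay. As far as these compounds go, whether the hydroxy group itself or its place on the ring goes with the step also stays open.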